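A few compounds are considered here, and "the series" means these few. Any claim that something is new, unique, unknown or untested is made for them only; others in the source may bear on it.

Compound 1 `Oc1ccc(-c2cc(-c3ccccc3F)cc(-c3ccccc3O)n2)cc1` gives > 50000 nM in a functional assay on HeLa cells (Homo sapiens) for inhibition (a higher number here means a weaker inhibitor, a lower number a stronger inhibitor), which is a limit of the assay rather than a number.
Compound 2 `Oc1ccc(-c2cc(-c3ccc(F)cc3)cc(-c3ccccc3O)n2)cc1` gives > 50000 nM, again a limit.
Compound 3 `Oc1ccc(-c2cc(-c3ccc(F)cc3)cc(-c3ccc(O)cc3)n2)cc1` gives 8680 nM.

Compound 2 therefore stands at a limit, and the limit of > 50000 nM in this assay, at which 2 of the 3 values shown sit, shows it shares that limit with one other compound. Compound 4 `Oc1ccc(-c2cc(-c3ccc(OC(F)(F)F)cc3)cc(-c3ccccc3O)n2)cc1` differs from compound 2 by trifluoromethoxy in place of fluoro on an aromatic carbon. Of the measured steps, a step that the two limits leave unreadable from compound 1 to compound 2 cannot be read, and an at least 5.7-fold lower number from compound 2 to compound 3 (0.76 log units; beyond the scatter) changes a hydroxyphenyl group, not the fluoro that is swapped here, so neither speaks directly to this change. With compound 2 only known as a limit, the step of a number no higher from compound 2 to compound 4 (the limit leaves the size open) is expected to be small, and compound 4 is estimated to remain weak, at 50000 nM within a range of 15000 nM to 200000 nM.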

Compound 4, half-maximal inhibitory concentration: > 50000 nM
Compound 4: no number, only a limit (the forecaster's own chance of this, stated with the estimate: 65%); the middle value sits exactly at the limit.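

Compound 2 and compound 4 both sit at a limit rather than a number, so the step between them cannot be read: the limit of > 50000 nM in this assay, at which 3 of the 4 values shown sit.

The compounds shown leave open whether trifluoromethoxy in place of fluoro changes inhibition at all.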